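A few compounds are considered here, and "the series" means these few. Any claim that something is new, unique, unknown or untested is made for them only; others in the source may bear on it.

Working notes on the series. Within the data shown here, compound 1 `O=C(NCCCCc1ccccc1)n1c(=O)oc2ccc(-c3ccc(F)cc3)cc21` is the reference point: in an assay on HEK293 cells for inhibition of acid ceramidase (Homo sapiens), with a stated time of 10 min (a higher number here means a weaker inhibitor, a lower number a stronger inhibitor), compound 1 gives 56 nM, and this is the only number in hand, since in this assay compound 2 `Cc1cccc2oc(=O)n(C(=O)NCCCCc3ccccc3)c12` gives no result reported. Compound 3 `O=C(NCCCCc1ccccc1)n1c(=O)oc2ccc([N+](=O)[O-])cc21` is not yet measured. It differs from compound 1 by nitro in place of 4-fluorophenyl on an aromatic carbon. Among the measured compounds shown here, no step between two measured compounds is available to anchor the change. The expected step of a 2.7-fold higher number from compound 1 to compound 3 (0.43 log units; beyond the scatter) is a modest move toward a weaker inhibitor, only marginally beyond the scatter. Compound 3 is thus estimated at 150 nM, within 40 nM to 600 nM.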

Compound 3, half-maximal inhibitory concentration: 3 nM
Compound 3: middle estimate off by 50-fold (1.70 log units), on the high side, outside the stated range (below it).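

In this assay, nitro in place of 4-fluorophenyl gives a 19-fold lower number from compound 1 to compound 3 (1.27 log units; beyond the scatter). This aromatic carbon therefore tolerates losing the six-membered aromatic ring, and a much smaller group with no ring gives the lower number. Nothing measured here bears on the origin of this step. Going by these compounds, the reading rests on a single pair, so it remains open whether the lower number is particular to nitro. An amine, a carboxylic acid or a methoxy group on the same aromatic carbon would test this.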